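The compounds below may be only part of what the source reports. "The series", "measured", "known", "first", "only" and "open" are said of these compounds alone.

Working notes on the series around compound 1 (`COc1cc(OC)c(OC)cc1/C=C/COC(=O)/C=C/c1ccc(OC)c(OC)c1`). In a functional assay on the whole organism (strain Kunming) with Mus musculus as the target, with a stated time of 0.5 h (on this read-out higher numbers stand for an effect only at larger amounts of compound and lower numbers for an effect already at smaller amounts), compound 1 gives 418 umol/kg and has no clear place of its own. Compound 2 (`COc1cc(OC)c(OC)cc1/C=C/COC(=O)/C=C/c1cc(OC)c(OC)c(OC)c1`) gives 459 umol/kg in the same read-out, and compound 3 (`COc1cc(OC)c(OC)cc1/C=C/COC(=O)/C=C/c1ccc(OC)c(OC)c1OC`) gives 456 umol/kg there, so all three lie within the scatter of one another.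

The open question is compound 4 (`COc1cc(OC)c(OC)cc1/C=C/COC(=O)/C=C/c1ccc(F)cc1`), which carries 4-fluorophenyl in place of 3,4-dimethoxyphenyl on a double-bonded chain carbon bound to a double-bonded chain carbon. Two measured steps alter this same aromatic group, each with methoxy in place of hydrogen on an aromatic carbon: a 1.1-fold higher number from compound 1 to compound 2 (0.04 log units; within the scatter) and a 1.1-fold higher number from compound 1 to compound 3 (0.04 log units; within the scatter) are both small. Among the measured compounds shown here, neither matches the present change, as no measured compound has a fluorine or lacks the methoxy groups on this ring. The evidence is therefore indirect and the range has to stay wide. Expected here is a 1.0-fold lower number from compound 1 to compound 4 (0.02 log units; within the scatter) in this assay, meaning no step beyond the scatter in either direction. Compound 4 is estimated at 400 umol/kg with an expected range from 200 umol/kg to 800 umol/kg in this read-out.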

Compound 4, dose for half-maximal effect: 449 umol/kg
Beside the measured number, compound 4's estimate is 1.1-fold (0.05 log units) below it, and the stated range covers the measured number.
By their numbers in this assay, from the lowest: compounds 1, 4, 3 and 2 (each within the scatter of the next).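

In this assay, 4-fluorophenyl in place of 3,4-dimethoxyphenyl on a double-bonded chain carbon bound to a double-bonded chain carbon gives a 1.1-fold higher number from compound 1 to compound 4 (0.03 log units; within the scatter) and so stays within the scatter. The earlier steps shown here only added a methoxy to this aromatic group, whereas this one removes both methoxy groups and brings in fluorine, so within these four compounds the number does not depend on the methoxy groups being present. The swap is also a larger one on the computed counts, going from 10 heavy atoms and 2 hydrogen-bond acceptors in the group that leaves to 7 heavy atoms and 0 hydrogen-bond acceptors in the group that enters, and no measured information explains why the read-out stays flat across it.

Going by these compounds, whether an amine or a carboxylic acid on this aromatic group would produce a step beyond the scatter stays open. Also open is whether any change elsewhere, such as a longer chain in the core of compound 1, would move the read-out, since every step shown so far alters this one aromatic group.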